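Isobutyl in Place of Fluoro on the Sulfonamide Aryl Ring

A few compounds are considered here, and "the series" means these few. Any claim that something is new, unique, unknown or untested is made for them only; others in the source may bear on it.

Compound 1 `O=C1NCCN1c1ccc(S(=O)(=O)Nc2ccc(F)cc2)cc1` is one of three closely related sulfonamides measured so far. In a functional assay on HT-29 cells (Homo sapiens) for antiproliferative activity, read by sulforhodamine B assay, with a stated time of 48 h (on this read-out higher numbers stand for weaker inhibition and lower numbers for stronger inhibition), compound 1 gives 370 nM, the highest of the three numbers. Compound 2 `Cc1ccc(NS(=O)(=O)c2ccc(N3CCNC3=O)cc2)cc1C` gives 230 nM and compound 3 `O=C1NCCN1c1ccc(S(=O)(=O)Nc2ccc(F)c(F)c2)cc1` gives 350 nM. The steps of a 1.6-fold lower number from compound 1 to compound 2 (0.21 log units; within the scatter) and a 1.1-fold lower number from compound 1 to compound 3 (0.02 log units; within the scatter) both lie within the scatter, as does a 1.5-fold higher number from compound 2 to compound 3 (0.18 log units; within the scatter), so the three compounds are not separated by these data.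

Compound 4 `CC(C)Cc1ccc(NS(=O)(=O)c2ccc(N3CCNC3=O)cc2)cc1` has not yet been measured. It differs from compound 1 by isobutyl in place of fluoro on an aromatic carbon. The most relevant guide is a 1.6-fold lower number from compound 1 to compound 2 (0.21 log units; within the scatter), where carbon groups entered the aryl ring of the sulfonamide and the number moved only slightly; a 1.1-fold lower number from compound 1 to compound 3 (0.02 log units; within the scatter) shows that a further small change on that ring also left the number in place. Compound 4 is therefore expected to give 250 nM, with a range from 100 nM to 700 nM. The expected step of a 1.5-fold lower number from compound 1 to compound 4 (0.17 log units; within the scatter) is estimated to remain within the scatter, leaning, if anywhere, toward a lower number.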

Compound 4, half-maximal inhibitory concentration: > 1000 nM
Compound 4: only a limit was reported (the forecaster's own chance of this, stated with the estimate: 5%); middle value at least 4.0-fold (0.60 log units) from the limit.
By their numbers in this assay, from the lowest: compounds 2, 3 and 1 (each within the scatter of the next). At a limit, above all of these: compound 4.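

Isobutyl in place of fluoro, para to a large group, is the first change on this aryl ring shown to move the number beyond the scatter in this assay: an at least 2.7-fold higher number from compound 1 to compound 4 (0.43 log units; beyond the scatter). The value for compound 4 is a limit and not a number: the limit of > 1000 nM in this assay, at which 1 of the 4 values shown sits. The ring substitutions in compound 2 and compound 3 stayed within the scatter of compound 1, so this place does not accept every carbon group alike, and isobutyl is the one group shown here that separates from the others.

On these data alone, how far compound 4 lies past its limit remains unknown, so the size of the step is only bounded from one side. The compounds shown also leave open whether branching or chain length matters, since a straight propyl or butyl chain, or an amine or a carboxylic acid at this place, does not appear among them.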